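The source may report more compounds than this note shows. Statements on the series, on what has been measured and on what is new or still open speak of the compounds shown alone.

Compound 3, `COc1ccc(N2CCN(Cc3csc(N)c3C(=O)c3ccc(Cl)cc3)CC2)cc1`, is one of three measured analogues built on a shared core. In a functional assay on CHO cells with adenosine receptor A1 (Homo sapiens) as the target, read by cAMP accumulation and immunoassay, with a stated time of 6 min, tested at 0.1 uM (on this read-out higher numbers stand for a weaker effect at the one concentration tested and lower numbers for a stronger effect), compound 3 gives 0%, the highest of the three numbers. Compound 1, `Nc1scc(CN2CCN(c3ccc(Cl)cc3Cl)CC2)c1C(=O)c1ccc(Cl)cc1`, gives -11%, and the change of 4-methoxyphenyl in place of 2,4-dichlorophenyl on an amine nitrogen in a ring brought a number 11 percentage points higher from compound 1 to compound 3 (beyond the scatter). Compound 2, `Nc1scc(CN2CCN(c3cc(Cl)cc(Cl)c3)CC2)c1C(=O)c1ccc(Cl)cc1`, gives -22%, and 4-methoxyphenyl in place of 3,5-dichlorophenyl on an amine nitrogen in a ring brought a number 22 percentage points higher from compound 2 to compound 3 (beyond the scatter). Between the two dichlorophenyl analogues, 3,5-dichlorophenyl in place of 2,4-dichlorophenyl brought a number 11 percentage points lower from compound 1 to compound 2 (beyond the scatter).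

Compound 4, `Nc1scc(CN2CCN(c3ccc([N+](=O)[O-])cc3)CC2)c1C(=O)c1ccc(Cl)cc1`, differs from compound 3 by nitro in place of methoxy on an aromatic carbon. All three measured steps concern the group on the amine nitrogen in a ring, but none of them exchanges methoxy for nitro, so they bear on the new step only as a measure of how much that position has moved the read-out, which was modest in every case. On that basis the step from compound 3 is expected to be small, with no confident direction, and possibly within the scatter: the estimated step is a number 3 percentage points lower from compound 3 to compound 4 (within the scatter). Compound 4 is thus estimated at -3%, within a range from -20% to 14%.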

Compound 4, a percentage reported as activity, at one concentration (the size of the read-out at that concentration, not a potency): -13%
For compound 4 the middle estimate is 10 percentage points above the measured one, within the range that was stated.
By their numbers in this assay, from the lowest: compounds 2, 4 and 1 (each within the scatter of the next, the first and the last beyond it); then compound 3.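

With the aromatic ring and the place of substitution kept and only the group para to a large group exchanged, the change gives a number 13 percentage points lower from compound 3 to compound 4 (beyond the scatter) in this assay and so shows that this one group alone can shift the read-out beyond the scatter, whereas each earlier step also altered the number or placing of the ring's substituents. The 4-nitrophenyl analogue also cannot be told apart from either dichlorophenyl analogue, with a number 9 percentage points higher from compound 2 to compound 4 (within the scatter) and a number 2 percentage points lower from compound 1 to compound 4 (within the scatter) even though those two analogues differ, with a number 11 percentage points lower from compound 1 to compound 2 (beyond the scatter) between them, which leaves compound 3 as the only one of the four whose steps to all the others are printed as beyond the scatter. Nothing available explains why methoxy and nitro part in this way or links the step to any property of either group.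

From the compounds shown here alone, whether an amine, a carboxylic acid or a nitrile on the same aromatic carbon would read with compound 3 or with compound 4 remains open. Also open, going by these compounds, is whether the step from methoxy to nitro would hold with the group elsewhere on the ring, or at other concentrations, since a read-out at a single concentration is not a potency.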